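A few compounds are considered here, and "the series" means these few. Any claim that something is new, unique, unknown or untested is made for them only; others in the source may bear on it.

Among the measured compounds shown here, in a functional assay on COLO 205 cells (Homo sapiens) for inhibition, read by sulforhodamine B assay (on this read-out higher numbers stand for weaker inhibition of growth and lower numbers for stronger inhibition of growth), compound 1 (`Cc1ccc2[nH]c(-c3ccc(-c4ccc(-c5ccc(N(C)C)cc5)cc4)cc3)nc2c1`) gives 9210 nM, the higher of the two numbers so far and therefore the weaker growth inhibition of the pair. Compound 2 (`COc1ccc(-c2ccc(-c3ccc(-c4nc5cc(C)ccc5[nH]4)cc3)cc2)cc1OC`) gives 2320 nM. For the measured compounds named here, the only measured step, a 4.0-fold lower number from compound 1 to compound 2 (0.60 log units; beyond the scatter), puts 3,4-dimethoxyphenyl in place of 4-(dimethylamino)phenyl.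

Compound 3 (`CN(C)c1ccc(-c2ccc(-c3ccc(-c4nc5c(O)cccc5[nH]4)cc3)cc2)cc1`) has not yet been measured. It keeps the 4-(dimethylamino)phenyl group of compound 1 and changes a different place: 4-hydroxy-1H-benzimidazol-2-yl in place of 5-methyl-1H-benzimidazol-2-yl on an aromatic carbon. In short, 4-hydroxy-1H-benzimidazol-2-yl stands in place of 5-methyl-1H-benzimidazol-2-yl on an aromatic carbon.

Going by the values given here, no measured pair tests this swap, so the data give no direct guide to its direction. The step of a 4.0-fold lower number from compound 1 to compound 2 (0.60 log units; beyond the scatter) bears on it only loosely, as a sign of how far one change in this small set has moved the number. A modest step is therefore a reasonable expectation, and a lower number is only a tentative lean. The estimated change is a 2.3-fold lower number from compound 1 to compound 3 (0.36 log units; beyond the scatter). For compound 3, the expected value is 4000 nM, with an estimated range of 1200 nM to 12000 nM.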

Compound 3, concentration for 50% growth inhibition: 6320 nM
The estimate for compound 3 lay 1.6-fold (0.20 log units) below the measured number; the range from low to high includes it.
By their numbers in this assay, from the lowest: compound 2; then compounds 3 and 1 (each within the scatter of the next).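

In this assay, replacing 5-methyl-1H-benzimidazol-2-yl with 4-hydroxy-1H-benzimidazol-2-yl gives a 1.5-fold lower number from compound 1 to compound 3 (0.16 log units; within the scatter), so this swap cannot be told apart from repeat-measurement noise, unlike the step beyond the scatter seen with a 4.0-fold lower number from compound 1 to compound 2 (0.60 log units; beyond the scatter). Among the compounds shown here, this is the first look at this part of the molecule, and it shows that the entering group, with 2 hydrogen-bond donors and 2 acceptors against 1 of each in the group it replaces, leaves growth inhibition indistinguishable from that of compound 1 in this one comparison. No measurement here explains this outcome.

From the compounds shown here alone, it remains open whether 4-hydroxy-1H-benzimidazol-2-yl would give a similar result when paired with the 3,4-dimethoxyphenyl group of compound 2, since only the 4-(dimethylamino)phenyl setting has been tested here. Going by these compounds, it is also open whether a different group on the benzimidazole, such as an amine or a carboxylic acid, would move the number beyond the scatter, or whether this position responds little to any change.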